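A few compounds are considered here, and "the series" means these few. Any claim that something is new, unique, unknown or untested is made for them only; others in the source may bear on it.

Two compounds share one core and differ only in the aryl group attached to the carbon that carries a double bond to nitrogen. Compound 1, `Cc1c(C(=O)N/N=C\c2c(O)cccc2Cl)oc2cccc(O)c12`, gives 18700 nM in a functional assay on PC-3 cells (Homo sapiens) for inhibition; a higher number here means a weaker inhibitor, a lower number a stronger inhibitor. Compound 2, `Cc1c(C(=O)N/N=C\c2cc(O)ccc2O)oc2cccc(O)c12`, gives 95500 nM in this assay, which is the highest of the two numbers measured; its nearest neighbour is compound 1, and the step of a 5.1-fold higher number from compound 1 to compound 2 (0.71 log units; beyond the scatter) lies beyond the scatter.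

Compound 3, `Cc1c(C(=O)N/N=C\c2cccc(O)c2)oc2cccc(O)c12`, is the next compound, not yet measured. It differs from compound 2 by hydrogen in place of hydroxy on an aromatic carbon, a change that, read one bond further out, turns 2,5-dihydroxyphenyl into 3-hydroxyphenyl. Among the compounds with values here, no measured step touches this hydroxy group: the only step known, a 5.1-fold higher number from compound 1 to compound 2 (0.71 log units; beyond the scatter), exchanges the whole aryl group together with its chloro substituent and so cannot be carried over to the loss of a single hydroxy. The direction of the change in this assay is therefore open, and the expectation rests on compound 2 alone, with a wide margin. Compound 3 is estimated at 45000 nM, between 12000 nM and 180000 nM, which means an expected step of a 2.1-fold lower number from compound 2 to compound 3 (0.33 log units; beyond the scatter).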

Compound 3, half-maximal inhibitory concentration: 17600 nM
Beside the measured number, compound 3's estimate is 2.6-fold (0.41 log units) above it, and the stated range covers the measured number.
By their numbers in this assay, from the lowest: compounds 3 and 1 (each within the scatter of the next); then compound 2.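

In this assay the hydroxy group on the aromatic carbon ortho to a large group and para to a hydroxy group now has a step of its own: replacing it with hydrogen gives a 5.4-fold lower number from compound 2 to compound 3 (0.73 log units; beyond the scatter) and so separates this single group from the exchange of the whole aryl group. This shows that the higher number of compound 2 goes with that extra hydroxy, and that the shared core reaches the range of compound 1 without it. The 3-hydroxyphenyl of compound 3 and the 2-chloro-6-hydroxyphenyl of compound 1 cannot be told apart here, with a 1.1-fold lower number from compound 1 to compound 3 (0.03 log units; within the scatter) as their step, and no evidence is available to explain the effect of the hydroxy group.

As far as these compounds go, whether a methoxy group, a fluorine atom or an amine on that same aromatic carbon would stay with compound 3 or move toward compound 2 remains open. So does what the hydroxy of the 3-hydroxyphenyl group contributes, since the compounds shown offer no step that removes it or replaces it with a methoxy group.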